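Dichloropurines on Lung Carcinoma Cells: a Fourth Compound Foreseen

The source may report more compounds than this note shows. Statements on the series, on what has been measured and on what is new or still open speak of the compounds shown alone.

Compound 1 `ClCc1ccc(Cn2cnc3c(Cl)ncnc32)cc1`: > 100000 nM
Compound 2 `ClCc1ccccc1Cn1cnc2ncnc(Cl)c21`: > 100000 nM
Compound 3 `ClCc1ccc(Cn2cnc3c(Cl)nc(Cl)nc32)cc1`: 97700 nM

In a functional assay on NCI-H522 cells (Homo sapiens) for cytotoxicity, read by sulforhodamine B assay, with a stated time of 48 h (a higher number here means that more compound is tolerated, a lower number that less compound is tolerated), compound 1 reaches only the assay limit of > 100000 nM, not a number. Compound 2 likewise gives only the limit > 100000 nM. Compound 3 gives a number in this assay, 97700 nM. The change from compound 1 to compound 3 is chloro in place of hydrogen on an aromatic carbon, and its step, an at least 1.0-fold lower number from compound 1 to compound 3 (0.01 log units; that floor lies within the scatter), stands at the floor of what can be read, which fits (the limit of > 100000 nM in this assay, at which 2 of the 3 values shown sit). How the cores of compound 1 and compound 2 differ is not broken down here. Compound 4 `ClCc1ccccc1Cn1cnc2nc(Cl)nc(Cl)c21` differs from compound 2 by chloro in place of hydrogen on an aromatic carbon, the same change. Because an at least 1.0-fold lower number from compound 1 to compound 3 (0.01 log units; that floor lies within the scatter) sits at the floor and the limit of > 100000 nM in this assay, at which 2 of the 3 values shown sit, caps two of three values, compound 4 is expected to move by about a number no higher from compound 2 to compound 4 (the limit leaves the size open). Compound 4 is therefore estimated at 100000 nM, likely between 50000 nM and 200000 nM, with a fair chance that only a limit is reported.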

Compound 4, concentration lethal to 50% of the cells: > 100000 nM
Compound 4: only a limit was reported; the forecaster's own chance of this, stated with the estimate: 60%; the middle value sits exactly at the limit.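

For the compounds shown here, no step from compound 2 to compound 4 can be read in this assay, because both compounds give only a limit there: the limit of > 100000 nM in this assay, at which 3 of the 4 values shown sit.

The compounds shown leave open whether chloro in place of hydrogen on an aromatic carbon changes the lethal concentration of compound 2 at all.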